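This account rests on a few compounds, and the source may have more. Where it says the series, first, only, none or still open, it means among the compounds named here.

Working notes on the series.

The shared core is that of compound 1 `COc1ccc2c(c1)CCC(Cc1ccccc1Br)C2=O`, which in an assay on CHO cells for inhibition of 1,25-dihydroxyvitamin D(3) 24-hydroxylase, mitochondrial (Homo sapiens) (a lower number here means a stronger inhibitor, a higher number a weaker inhibitor), gives 16300 nM. Compound 2 `COc1ccc2c(c1)CCC(Cc1ccccc1-c1ccccc1)C2=O` gives 128000 nM in this assay, and compound 3 `COc1ccc2c(c1)CCC(Cc1ccccc1/C=C/c1ccccc1)C2=O` gives 343000 nM. Compound 3 thus stands at the highest number of the three: the step of a 21-fold higher number from compound 1 to compound 3 (1.32 log units; beyond the scatter) is large, the step of a 2.7-fold higher number from compound 2 to compound 3 (0.43 log units; beyond the scatter) modest, and a 7.9-fold higher number from compound 1 to compound 2 (0.90 log units; beyond the scatter) fills in the intermediate position of compound 2.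

Compound 4 `COc1ccc2c(c1)CCC(Cc1ccccc1CCc1ccccc1)C2=O` differs from compound 3 by phenethyl in place of 2-phenylethenyl on an aromatic carbon. Among the compounds with values here, no measured step tests this exact exchange; the nearest is a 2.7-fold higher number from compound 2 to compound 3 (0.43 log units; beyond the scatter), where a group of the same ring count grew by a two-carbon link and the number rose modestly. Compound 4 keeps the same heavy-atom count and ring as compound 3, so the expected step of a 1.1-fold higher number from compound 3 to compound 4 (0.04 log units; within the scatter) is small, likely within the scatter, with a slight bias toward a higher number given the trend across compounds 1, 2 and 3. For compound 4 the estimate in this assay is 380000 nM, expected to lie between 140000 nM and 1000000 nM.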

Compound 4, half-maximal inhibitory concentration: 25600 nM
The estimate for compound 4 lay 15-fold (1.17 log units) above the measured number, and the stated range ends above it.
By their numbers in this assay, from the lowest: compounds 1 and 4 (each within the scatter of the next); then compound 2; then compound 3.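

Replacing 2-phenylethenyl with phenethyl on this aromatic carbon removes only the double bond outside aromatic rings, leaving the counted heavy atoms and the ring unchanged, yet in this assay it gives a 13-fold lower number from compound 3 to compound 4 (1.13 log units; beyond the scatter). The rise in the number seen from bromo through phenyl to 2-phenylethenyl does not extend to phenethyl: compound 4 goes against it with a 5.0-fold lower number from compound 2 to compound 4 (0.70 log units; beyond the scatter) and returns to the level of the bromo compound with a 1.6-fold higher number from compound 1 to compound 4 (0.20 log units; within the scatter). Nothing at hand explains why the saturated link behaves so differently from the unsaturated one.

As far as these compounds go, whether a longer chain such as 3-phenylpropyl keeps the number of compound 4 remains open. So does the effect of an ether oxygen or an amine in the link, or of a carboxylic acid on the terminal phenyl ring.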